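Changing the Benzyl Group on an Inactive Compound

This account rests on a few compounds, and the source may have more. Where it says the series, first, only, none or still open, it means among the compounds named here.

Measured in a functional assay on CCRF-CEM cells (Homo sapiens) for antiproliferative activity, with a stated time of 72 h; on this read-out lower numbers stand for stronger inhibition and higher numbers for weaker inhibition:
- compound 1 `OC[C@H]1O[C@@H](n2cnc3c(NCc4ccccc4Br)ncnc32)[C@H](O)[C@@H]1O`: 12300 nM
- compound 2 `Cc1ccc(CNc2ncnc3c2ncn3[C@@H]2O[C@H](CO)[C@@H](O)[C@H]2O)cc1`: > 166000 nM

Compound 2 has no exact number, only a limit, > 166000 nM. Compound 2 stands at the limit of > 166000 nM in this assay, at which 1 of the 2 values shown sits.

Compound 3 `COc1cccc(CNc2ncnc3c2ncn3[C@@H]2O[C@H](CO)[C@@H](O)[C@H]2O)c1` carries 3-methoxyphenyl in place of 4-methylphenyl on a saturated chain carbon bound to a nitrogen on an aromatic ring.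

Within the data shown here, only one measured step bears on this change. It is an at least 13-fold higher number from compound 1 to compound 2 (1.13 log units; beyond the scatter), and it is large and made at the same place. That step involves a different pair of groups, so it shows that this place can matter but does not fix the size of the next change. Compound 1 at 12300 nM shows that a real number is within reach in this assay. A moderate move towards lower numbers is therefore expected, though another limit remains quite possible.

The estimated step is an at least 3.3-fold lower number from compound 2 to compound 3 (0.52 log units; beyond the scatter). Compound 3 is expected at 50000 nM, with an estimated range of 10000 nM to 166000 nM.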

Compound 3, half-maximal inhibitory concentration: 7600 nM
The estimate for compound 3 lay 6.6-fold (0.82 log units) above the measured number, and the stated range ends above it.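

Swapping 4-methylbenzyl for 3-methoxybenzyl gives an at least 21-fold lower number from compound 2 to compound 3 (1.33 log units; beyond the scatter), so the failure of compound 2 to reach a measured number in this assay goes with that one group and not with the shared core. Compound 2 has only a limit and not an exact number, so the true size of this step stays unknown: the limit of > 166000 nM in this assay, at which 1 of the 3 values shown sits.

The comparison between the two groups that do give numbers is a 1.6-fold lower number from compound 1 to compound 3 (0.21 log units; within the scatter), so 2-bromophenyl and 3-methoxyphenyl cannot be told apart in this assay, even though they differ in both the group on the ring and its place there.

The compounds shown leave open whether the large step from compound 2 to compound 3 comes from exchanging the methyl group for the methoxy group or from where each group sits on the ring. They also leave open how this position would respond to something quite different on the ring, such as an amine or a carboxylic acid, or to a longer chain in place of the benzyl link.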